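The source may report more compounds than this note shows. Statements on the series, on what has been measured and on what is new or still open speak of the compounds shown alone.

Measured in an ADME assay on MT4 cells (Homo sapiens) for cytotoxicity, read by MTT assay, with a stated time of 5 days; on this read-out higher numbers stand for lower toxicity in this test and lower numbers for higher toxicity in this test:
- compound 1 `N#Cc1ccc(Nc2nccc(C(O)c3ccc(-c4ccc(C#N)cc4)cc3F)n2)cc1`: 14300 nM
- compound 2 `N#Cc1ccc(Nc2nccc([C@H](O)c3ccc(-c4ccc(C#N)cc4)cc3F)n2)cc1`: 30000 nM
- compound 3 `N#Cc1ccc(Nc2nccc([C@@H](O)c3ccc(-c4ccc(C#N)cc4)cc3F)n2)cc1`: 7500 nM

Compound 2 carries the highest number of the three, and compound 3 the lowest of the two single configurations. Next in this assay is compound 4 `Cc1cc(-c2ccc(C#N)cc2)ccc1[C@@H](O)c1ccnc(Nc2ccc(C#N)cc2)n1`, which departs from compound 2 by methyl in place of fluoro on an aromatic carbon, ortho to a large group and meta to a 4-cyanophenyl group.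

Among the measured compounds shown here, no measured step makes this exchange. All three concern configuration only: a 2.1-fold higher number from compound 1 to compound 2 (0.32 log units; beyond the scatter), a 1.9-fold lower number from compound 1 to compound 3 (0.28 log units; within the scatter) and a 4.0-fold lower number from compound 2 to compound 3 (0.60 log units; beyond the scatter), the last of these accompanying (the fact that compounds 2 and 3 differ only in the configuration as drawn). They give a rough size for movement in this small series, but no direction for the new change. With compound 2 at the top at 30000 nM, a slight move down is expected, though nothing beyond the scatter: the expected step is a 1.3-fold lower number from compound 2 to compound 4 (0.12 log units; within the scatter). For compound 4 the estimated value is 23000 nM, with an expected range from 9000 nM to 60000 nM.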

Compound 4, half-maximal cytotoxic concentration: 35600 nM
For compound 4 the middle estimate is 1.5-fold (0.19 log units) below the measured one; the measured number falls inside the stated range.
By their numbers in this assay, from the lowest: compounds 3 and 1 (each within the scatter of the next); then compounds 2 and 4 (each within the scatter of the next).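

In this assay, among the compounds shown here, methyl in place of fluoro on an aromatic carbon gives a 1.2-fold higher number from compound 2 to compound 4 (0.07 log units; within the scatter) as the first reading at this position, since the earlier compounds varied only in configuration. This place, ortho to a large group and meta to a 4-cyanophenyl group, takes either group without a move beyond the scatter, whereas a 4.0-fold lower number from compound 2 to compound 3 (0.60 log units; beyond the scatter) remains the larger movement in the series and belongs to the stereocentre. Nothing on hand gives a reason for the step between fluoro and methyl.

Open, on these data alone, is whether a larger or different group at this place, such as methoxy, an amine or trifluoromethyl, would keep the number in the same region. Also open, as far as these compounds go, is how the methyl compound behaves in the opposite configuration, and so whether the gap between the two configurations carries over from the fluoro pair.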